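The source may report more compounds than this note shows. Statements on the series, on what has been measured and on what is new or still open speak of the compounds shown alone.

Working notes on the series, measured in an ADME assay on BHK-21 cells (Mesocricetus auratus) for cytotoxicity, read by MTT assay; on this read-out higher numbers stand for lower toxicity in this test and lower numbers for higher toxicity in this test:

- compound 1 `C/C(=N\O)c1ccc2[nH]c(-c3ccccc3)nc2c1`: > 100000 nM (a limit, not a number)
- compound 2 `C/C(=N\O)c1ccc2[nH]c(-c3ccc(Cl)cc3)nc2c1`: 33000 nM
- compound 3 `C/C(=N\O)c1ccc2[nH]c(-c3ccc(C(F)(F)F)cc3)nc2c1`: "not determined" (no result reported)

Going by the values given here, compound 2, at 33000 nM, holds the only true number. The entry for compound 1 is a limit. Compound 3 gave no result to compare.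

Compound 4 `C/C(=N\NC(N)=O)c1ccc2[nH]c(-c3ccc(Cl)cc3)nc2c1` has not yet been measured in this assay. It carries ureido in place of hydroxy on a double-bonded nitrogen of compound 2: ureido in place of hydroxy on a double-bonded nitrogen.

Among the compounds with values here, the one measured step is an at least 3.0-fold lower number from compound 1 to compound 2 (0.48 log units; beyond the scatter), and it starts from the limit. That step is chloro in place of hydrogen on an aromatic carbon, so it is a different change at a different place. Within the data shown here, it shows only that this read-out can move, and no measured step covers the new change. No shift beyond the scatter is therefore expected, and the estimated change is a 1.2-fold higher number from compound 2 to compound 4 (0.08 log units; within the scatter). For compound 4 the expected value is 40000 nM, with an estimated range of 13000 nM to 100000 nM.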

Compound 4, half-maximal cytotoxic concentration: > 100000 nM
Compound 4 ended at the assay's limit; the forecaster's own chance of this, stated with the estimate: 25%; middle value at least 2.5-fold (0.39 log units) away from the limit.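

In this assay, ureido in place of hydroxy on a double-bonded nitrogen gives an at least 3.0-fold higher number from compound 2 to compound 4 (0.48 log units; beyond the scatter). This shows that the read-out responds to a change at this nitrogen, whereas the earlier step covered only an aromatic carbon, and that the number found with chloro present does not hold once hydroxy is replaced. The value of compound 4 is a limit and not a number, so the step gives only a minimum size: the limit of > 100000 nM in this assay, at which 2 of the 4 values shown sit.

The compounds shown do not separate the effect of adding ureido from that of losing hydroxy, a question that an amine or a methoxy group on the same double-bonded nitrogen would address. Going by these compounds, it also stays open whether the step persists with a group other than chloro on the aromatic carbon, such as methyl or a carboxylic acid.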